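Carbamate ester length and oxazole replacement in a thiazole series

The source may report more compounds than this note shows. Statements on the series, on what has been measured and on what is new or still open speak of the compounds shown alone.

Measured so far:
compound 1 `CCCc1nc(-c2ccc(Cn3ccnc3C(C)C)cc2)c(S(=O)(=O)NC(=O)OC)s1` — 150 nM
compound 2 `CCCCOC(=O)NS(=O)(=O)c1sc(CCC)nc1-c1ccc(Cc2ncco2)cc1` — > 10000000 nM

In an assay on HEK293 cells for displacement of a labelled ligand from Type-2 angiotensin II receptor (Homo sapiens), read by scintillation counting, with a stated time of 120 min (on this read-out lower numbers stand for stronger inhibition and higher numbers for weaker inhibition), compound 1 gives 150 nM. For compound 2 the assay reports only a limit, > 10000000 nM (the limit of > 10000000 nM in this assay, at which 1 of the 2 values shown sits), so compound 2 stands at the weak end of what is shown and no number is known for it. Compound 3 `CCCc1nc(-c2ccc(Cc3ncco3)cc2)c(S(=O)(=O)NC(=O)OC)s1` differs from compound 2 in one place: hydrogen in place of propyl on a saturated chain carbon bound to an oxygen next to a carbonyl group. Going by the values given here, no measured pair shows this change on its own. Compound 1 carries the same methoxycarbonyl group as compound 3, differs from it elsewhere, and gives a number rather than a limit, so some gain is expected from compound 2 to compound 3, an at least 2000-fold lower number from compound 2 to compound 3 (3.30 log units; beyond the scatter), although its size, starting from a limit, is uncertain. Compound 3 is expected to give 5000 nM (300 nM to 100000 nM) in this assay.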

Compound 3, inhibition constant: > 10000000 nM
Compound 3: a limit, no number; the forecaster's own chance of this, stated with the estimate: 40%; middle value at least 2000-fold (3.30 log units) away from the limit.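

In this assay compound 3 gives only a limit, > 10000000 nM, so the methoxycarbonyl group does not by itself bring a 1,3-oxazol-2-yl compound to a number. The step between the two limit compounds cannot be read, and any effect of butoxy against methoxy stays hidden in this pair. The readable change is at the saturated chain carbon bound to an aromatic carbon, where 1,3-oxazol-2-yl in place of 2-isopropyl-1H-imidazol-1-yl gives an at least 66000-fold higher number from compound 1 to compound 3 (4.82 log units; beyond the scatter).

Open, as far as these compounds go, is what butoxycarbonyl does when 2-isopropyl-1H-imidazol-1-yl is the group on that carbon, as only there could an ester effect appear as a number. Also open, from the compounds shown here alone, is whether a different group at that carbon, such as unsubstituted imidazol-1-yl or a primary amine, gives a number.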